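Methyl for Chloro on the Pyridine Ring

A few compounds are considered here, and "the series" means these few. Any claim that something is new, unique, unknown or untested is made for them only; others in the source may bear on it.

Compound 1 `CNCc1cn(S(=O)(=O)c2cc(OC)ccn2)c(-c2cccnc2F)c1F` gives 95% in a functional assay on the whole organism (strain Jcl:Sprague-Dawley) for inhibition, with Rattus norvegicus as the target, with stated times of 3 min and 3 h, at a dose of 1 mg/kg by the intravenous route; on this read-out higher numbers stand for more inhibition at the one dose given (going by the name of the read-out) and lower numbers for less inhibition. Compound 2 `CNCc1cn(S(=O)(=O)c2cccnc2Cl)c(-c2cccnc2F)c1F` gives "not determined" (no result reported) in this assay, so no single number places it. Compound 3 `CNCc1cn(S(=O)(=O)c2cccnc2C)c(-c2cccnc2F)c1F` differs from compound 2 in one place: methyl in place of chloro on an aromatic carbon. Among the measured compounds shown here, with no measured steps to draw on, the most that can be expected for compound 3 in this assay is a read-out near that of compound 1, with no shift beyond the usual scatter in either direction. Compound 3 is therefore estimated at 85%, in a range from 55% to 100%.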

Compound 3, a percentage reported as inhibition, in the whole organism at one dose (the size of the read-out at that dose, not a potency): 92%
The estimate for compound 3 lay 7 percentage points below the measured number; the measured number falls inside the stated range.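

In this assay, among the compounds shown here, the 2-methylpyridin-3-yl group gives the first reading for this pyridine attachment on the sulfonyl sulfur, and the step reads a number 3 percentage points lower from compound 1 to compound 3 (within the scatter). Exchanging 4-methoxypyridin-2-yl for this group therefore leaves the read-out within the scatter, while compound 2 has no reported result, and the change from chloro to methyl cannot be read. No available evidence bears on why these two sulfonyl substituents read alike. Still open, from the compounds shown here alone, is how an amine or an ethyl group in place of the methyl would read. Going by these compounds, at this single dose, any difference in potency between compound 1 and compound 3 also stays open.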